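Dropping the nitro group from an indole-derived acrylate

A few compounds are considered here, and "the series" means these few. Any claim that something is new, unique, unknown or untested is made for them only; others in the source may bear on it.

The compounds share the core of compound 1 `CC(=O)/C(=C/c1c(-c2ccccc2)[nH]c2ccccc12)C(=O)c1ccccc1`, a 2-phenylindole bearing an exocyclic alkene carrying two electron-withdrawing substituents. In a functional assay on DU-145 cells (Homo sapiens) for cytotoxicity, read by MTT assay, with a stated time of 96 h (a lower number here means that less compound is needed, a higher number that more compound is needed for the effect), compound 1 gives only a limit, > 100000 nM. That outcome matches (the limit of > 100000 nM in this assay, at which 1 of the 3 values shown sits). Compound 2 `CCOC(=O)/C(=C/c1c(-c2ccccc2)[nH]c2ccccc12)C(=O)c1ccc([N+](=O)[O-])cc1`, which carries an ethyl ester and a (4-nitrophenyl)carbonyl group, is measured in this assay at 11000 nM. Compound 3 `COCCOC(=O)/C(C#N)=C/c1c(-c2ccccc2)[nH]c2ccccc12`, with a nitrile beside a methoxyethyl ester, is measured at 4200 nM. Among the two numbers available, compound 2 therefore stands highest, and its gap to compound 3 lies beyond the usual scatter.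

Compound 4 `CCOC(=O)/C(=C/c1c(-c2ccccc2)[nH]c2ccccc12)C(=O)c1ccccc1` has not yet been measured. It differs from compound 2 in a single place: hydrogen in place of nitro on an aromatic carbon. Within the data shown here, no measured pair of compounds traces exactly this change, so the size of the step has to be inferred. Compound 1, which also carries a plain benzoyl group, reaches only the limit, and this points toward a weaker result for compound 4 than for compound 2, though the scale of that step is uncertain. The author expects the step from compound 2 to compound 4 to be a 2.7-fold higher number from compound 2 to compound 4 (0.44 log units; beyond the scatter). In this assay compound 4 is estimated at 30000 nM, with a likely range from 10000 nM to 100000 nM.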

Compound 4, half-maximal effective concentration: 68000 nM
The estimate for compound 4 lay 2.3-fold (0.36 log units) below the measured number; measured number inside the range.
By their numbers in this assay, from the lowest: compound 3; then compound 2; then compound 4. At a limit, above all of these: compound 1.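

Within this assay, the nitro group on an aromatic carbon, para to a large group, now has a direct measure: replacing it with hydrogen gives a 6.2-fold higher number from compound 2 to compound 4 (0.79 log units; beyond the scatter), so in this ester series the change from (4-nitrophenyl)carbonyl to benzoyl clearly costs activity. The plain benzoyl compound also gives a number rather than a limit, and ethoxy in place of methyl on a carbonyl carbon can be read only as an at least 1.4-fold lower number from compound 1 to compound 4 (0.16 log units; that floor lies within the scatter), which rests on the limit of compound 1 and so establishes no real difference between the two. Nothing measured in this set bears on why the nitro group matters.

From the compounds shown here alone, what remains open is whether the gain belongs to nitro itself or would also appear with another group at this place, such as an amine, a chlorine atom or a methoxy group. Going by these compounds, it is also open how far the ester can be altered with the nitro group in place, for instance by a carboxylic acid or a longer chain in place of the ethyl ester.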